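A few compounds are considered here, and "the series" means these few. Any claim that something is new, unique, unknown or untested is made for them only; others in the source may bear on it.

Going by the values given here, in an ADME assay on Vero cells (Chlorocebus sabaeus) for cytotoxicity, with a stated time of 24 h (on this read-out lower numbers stand for higher toxicity in this test and higher numbers for lower toxicity in this test), compound 2 `CCC(CC)O[C@@H]1C=C(C(=O)Nc2ccccc2OC)C[C@H](NC(=O)OC(C)(C)C)[C@H]1NC(C)=O` gives 755000 nM, the higher of the two numbers known so far, while compound 1 `CCC(CC)O[C@@H]1C=C(C(=O)Nc2ccccc2)C[C@H](N)[C@H]1NC(C)=O` gives 153000 nM, a gap beyond the usual scatter. Compound 3 `CCC(CC)O[C@@H]1C=C(C(=O)Nc2ccccc2OC)C[C@H](N)[C@H]1NC(C)=O` comes from compound 2 through one change, hydrogen in place of tert-butoxycarbonyl on an amine nitrogen. Compound 1 carries the same hydrogen on that nitrogen and stands at 153000 nM, so a lower number is expected. The expected change is a 3.4-fold lower number from compound 2 to compound 3 (0.54 log units; beyond the scatter), which would lie beyond the scatter. For compound 3 the estimated value is 220000 nM, with an expected range from 90000 nM to 500000 nM.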

Compound 3, half-maximal cytotoxic concentration: 155000 nM
Compound 3: middle estimate off by 1.4-fold (0.15 log units), on the high side; measured number inside the range.
By their numbers in this assay, from the lowest: compounds 1 and 3 (each within the scatter of the next); then compound 2.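

Removing tert-butoxycarbonyl from the amine nitrogen gives a 4.9-fold lower number from compound 2 to compound 3 (0.69 log units; beyond the scatter) in this assay as a single change, which the earlier pair, differing in two places, could not isolate. Methoxy in place of hydrogen on the aromatic carbon gives a 1.0-fold higher number from compound 1 to compound 3 (0.01 log units; within the scatter) when the amine carries hydrogen, so that change does not separate the two compounds in this test. No evidence here explains either step.

Going by these compounds, whether the tert-butoxycarbonyl step is the same without the methoxy group stays open. So does where an acetyl or methyl group on that nitrogen would fall.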